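Bromothiophene in place of aminophenyl on the ketone

The source may report more compounds than this note shows. Statements on the series, on what has been measured and on what is new or still open speak of the compounds shown alone.

The series shares the core of compound 1 `COc1ccc(-c2cc3ccccc3nc2/C=C/C(=O)c2ccc(F)cc2)cc1` and is read in a functional assay on H184B5F5/M10 cells (Homo sapiens) for antiproliferative activity, read by XTT assay, with a stated time of 72 h; on this read-out higher numbers stand for weaker inhibition and lower numbers for stronger inhibition. Compound 1 reaches only the limit of the assay, > 10000 nM. Compound 2 `COc1ccc(-c2cc3ccccc3nc2/C=C/C(=O)c2ccc(O)cc2)cc1` gives 5690 nM. Compound 3 `COc1ccc(-c2cc3ccccc3nc2/C=C/C(=O)c2ccc(N)cc2)cc1` gives 9290 nM, not separated from compound 2 beyond the scatter, as a 1.6-fold higher number from compound 2 to compound 3 (0.21 log units; within the scatter) shows; an at least 1.7-fold lower number from compound 1 to compound 2 (0.24 log units; that floor lies within the scatter) and an at least 1.0-fold lower number from compound 1 to compound 3 (0.03 log units; that floor lies within the scatter) likewise stay inside the scatter. Compound 4 `COc1ccc(-c2cc3ccccc3nc2/C=C/C(=O)c2ccc(Br)s2)cc1` differs from compound 3 by 5-bromothiophen-2-yl in place of 4-aminophenyl on a carbonyl carbon. Going by the values given here, no measured step replaces the aromatic ring on the carbonyl carbon; the steps that vary only its substituent were all small, so no change beyond the scatter is expected in this assay, with a real chance of another limit. Compound 4 is expected at 9000 nM, within 3000 nM to 30000 nM. The expected step is a 1.0-fold lower number from compound 3 to compound 4 (0.01 log units; within the scatter).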

Compound 4, half-maximal inhibitory concentration: 9380 nM
For compound 4 the middle estimate is 1.0-fold (0.02 log units) below the measured one; measured number inside the range.
By their numbers in this assay, from the lowest: compounds 2, 3 and 4 (each within the scatter of the next). At a limit, above all of these: compound 1.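

In this assay, the exchange of the six-membered carbon ring for 5-bromothiophen-2-yl on a carbonyl carbon leaves the number within the scatter of both neighbours (a 1.0-fold higher number from compound 3 to compound 4 (0.00 log units; within the scatter); a 1.6-fold higher number from compound 2 to compound 4 (0.22 log units; within the scatter)). The result extends what the substituent steps showed: here the ring itself changes, and the hydrogen-bond donor of 4-aminophenyl leaves, without a separable shift. Compound 1 is a limit, and its step gives only a floor (an at least 1.0-fold lower number from compound 1 to compound 4 (0.02 log units; that floor lies within the scatter)), a limit seen once in the series: the limit of > 10000 nM in this assay, at which 1 of the 4 values shown sits.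

Open, from the compounds shown here alone, is whether unsubstituted thiophen-2-yl, or a saturated ring amine such as piperidine on the carbonyl carbon, would give a step beyond the scatter.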